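A few compounds are considered here, and "the series" means these few. Any claim that something is new, unique, unknown or untested is made for them only; others in the source may bear on it.

Compound 1 `Fc1ccc(-c2nc3sc(Cc4ccc(Cl)cc4)nn3c2Br)cc1` and compound 2 `Cc1ccc(-c2nc3sc(Cc4ccc(Cl)cc4)nn3c2Br)cc1` share one core and differ at one aromatic carbon. In a functional assay on L1210 cells (Mus musculus) for cytotoxicity, with a stated time of 48 h (on this read-out higher numbers stand for weaker inhibition and lower numbers for stronger inhibition), compound 1 reaches only the assay limit, > 250000 nM. In this assay compound 2 likewise stops at the limit, > 250000 nM. The step that the two limits leave unreadable from compound 1 to compound 2 is therefore not readable, both values resting at the limit of > 250000 nM in this assay, at which 2 of the 2 values shown sit. Compound 3 `Clc1ccc(Cc2nn3c(Br)c(-c4ccc(Cl)cc4Cl)nc3s2)cc1` carries 2,4-dichlorophenyl in place of 4-methylphenyl on an aromatic carbon. Among the measured compounds shown here, no measured step resolves this kind of change, so nothing indicates that compound 3 will leave the limit. The estimate for compound 3 is 300000 nM, in a range from 100000 nM to 1000000 nM. The implied step that the limit leaves unreadable from compound 2 to compound 3 is expected to remain unreadable.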

Compound 3, half-maximal inhibitory concentration: 31000 nM
For compound 3 the middle estimate is 9.7-fold (0.99 log units) above the measured one; measured number below the stated range.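

This aromatic carbon can move the read-out off the limit. In this assay, compound 3 gives a real number, 31000 nM. With 2,4-dichlorophenyl in place, the series shows an at least 8.0-fold lower number from compound 2 to compound 3 (0.90 log units; beyond the scatter) and an at least 8.0-fold lower number from compound 1 to compound 3 (0.90 log units; beyond the scatter). Both sizes are only lower bounds, and compounds 1 and 2 remain limits, not numbers: the limit of > 250000 nM in this assay, at which 2 of the 3 values shown sit.

On these data alone, whether one chlorine would suffice, as in 4-chlorophenyl or 2-chlorophenyl, stays open. Also open, as far as these compounds go, is how an amine or a carboxylic acid on this phenyl ring would read.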